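The source may report more compounds than this note shows. Statements on the series, on what has been measured and on what is new or still open speak of the compounds shown alone.

Measured compounds:
compound 1, `CCOC(=O)C1=C(c2ccccc2)NC(=O)NC1c1ccco1`, 2%
compound 2, `CCOC(=O)C1=C(C)N(C)C(=O)NC1c1ccco1`, 25%
compound 3, `CC1=C(C(=O)OC(C)C)C(c2ccco2)NC(=O)N1C`, 18%

In an assay on HeLa cells for displacement of a labelled ligand from adenosine receptor A3 (Homo sapiens), with a stated time of 180 min, tested at 10 uM (on this read-out lower numbers stand for less inhibition and higher numbers for more inhibition at the one concentration tested (going by the name of the read-out)), compound 2 gives the highest of the three numbers. Compound 3 is nearest to it, and the step of a number 7 percentage points lower from compound 2 to compound 3 (within the scatter) lies within the scatter, so the two cannot be ranked. Going by the values given here, compound 1 is furthest; its value sits beyond the scatter below that of compound 2, and no single-change step joins these two, so only their two values speak.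

Compound 4, `CCOC(=O)C1=C(C)N(C)C(=O)NC1c1cccs1`, has not yet been measured. It differs from compound 2 in one place: thiophen-2-yl in place of furan-2-yl on a saturated ring carbon. Among the compounds with values here, the only measured step, a number 7 percentage points lower from compound 2 to compound 3 (within the scatter), alters a different part of the molecule and was within the scatter, so it does not bear on this change. Within the data shown here, no measured pair shows what exchanging furan-2-yl for thiophen-2-yl does here. In this assay the expectation is therefore no step beyond the scatter. The expected step for compound 4 is no change at the digits printed from compound 2 to compound 4 (within the scatter). The estimate for compound 4 is 25%, within the range 10% to 40%.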

Compound 4, a percentage reported as inhibition, at one concentration (the size of the read-out at that concentration, not a potency): 6%
Estimate against measurement, compound 4: 19 percentage points above, outside the stated range (below it).
By their numbers in this assay, from the lowest: compounds 1 and 4 (each within the scatter of the next); then compounds 3 and 2 (each within the scatter of the next).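

In this assay, going by these compounds alone, the exchange of furan-2-yl for thiophen-2-yl on the saturated ring carbon gives a number 19 percentage points lower from compound 2 to compound 4 (beyond the scatter), so this position responds to a change in the ring attached there, which the earlier compounds could not show. The two groups have the same counts of heavy atoms, hydrogen-bond donors and hydrogen-bond acceptors, and both are five-membered aromatic rings; the difference is a ring sulfur in place of a ring oxygen. No measurement shown here explains the size or direction of this step.

Going by these compounds, what a pyridin-2-yl or a cyclohexyl group would give at this position remains open. Also open, on these data alone, is whether the same exchange would give a similar step with an isopropyl ester in place of the ethoxycarbonyl group.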